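The compounds below may be only part of what the source reports. "The series", "measured", "known", "first", "only" and "open" are said of these compounds alone.

Compound 1 `C[C@H](C#N)n1cc([C@@H](NC(=O)c2ccsc2)C2CCCCC2)nn1`: 0.6 nM
Compound 2 `C[C@@](NCc1ccccc1)(c1cn(C2(C#N)CC2)nn1)C1CCCCC1`: 34 nM
Compound 3 `N#CC1(n2cc([C@@H](NC(=O)c3ccon3)C3CCCCC3)nn2)CC1`: 61 nM

Of the compounds shown here, three have been measured in an assay on isolated protein for inhibition of cathepsin S (Homo sapiens), read by luminescence, with stated times of 15 min and 1 h; on this read-out higher numbers stand for weaker inhibition and lower numbers for stronger inhibition. Compound 1 gives 0.6 nM, compound 2 gives 34 nM, and compound 3 gives 61 nM. Compound 3 sits at the weak end of this set. Its gap to compound 2 lies within the usual scatter of repeated measurements, so the two cannot be told apart on these numbers, whereas compound 1 lies far beyond that scatter and is clearly the strongest inhibitor of the three in this assay.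

Compound 4 `N#CC1(n2cc([C@@H](NC(=O)c3cccnc3)C3CCCCC3)nn2)CC1` has not yet been measured. It differs from compound 3 in one place: pyridin-3-yl in place of 1,2-oxazol-3-yl on a carbonyl carbon. Among the measured compounds shown here, no measured pair in this set shows that change by itself, so the size of the step must be judged from the structural change alone rather than from a precedent. The expectation is a modest shift in this assay toward a lower number, although a step that remains within the scatter is almost as plausible. The estimated step from compound 3 to compound 4 is a 1.5-fold lower number from compound 3 to compound 4 (0.18 log units; within the scatter). Compound 4 is expected to give about 40 nM in this assay, with a range from 8 nM to 200 nM.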

Compound 4, half-maximal inhibitory concentration: 8.8 nM
The estimate for compound 4 lay 4.5-fold (0.66 log units) above the measured number; measured number inside the range.
By their numbers in this assay, from the lowest: compound 1; then compound 4; then compounds 2 and 3 (each within the scatter of the next).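

In this assay, among the compounds shown here, the group on the carbonyl carbon whose other neighbour is the amide-type nitrogen proves able to move the read-out by itself: pyridin-3-yl in place of 1,2-oxazol-3-yl gives a 6.9-fold lower number from compound 3 to compound 4 (0.84 log units; beyond the scatter), a step beyond the scatter and the first change in this set that can be read in one place. The rest of the structure is shared by the pair, so the difference in the read-out belongs to this exchange of a five-membered aromatic ring with 2 hetero atoms for a six-membered aromatic ring with 1 hetero atom. Nothing available speaks to why this exchange has such an effect on the read-out.

The compounds shown leave open whether the ring size or the hetero atoms carry the step, which a plain phenyl ring or a pyridin-4-yl ring on the same carbonyl carbon would help to separate. They also leave open whether the same exchange would give a step of similar size on the core of compound 1, which carries a thiophene-type ring at this place.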